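The source may report more compounds than this note shows. Statements on the series, on what has been measured and on what is new or still open speak of the compounds shown alone.

In an ADME assay on microsomes from liver (Mus musculus) for metabolic stability, read by HPLC, with a stated time of 4 h (on this read-out higher numbers stand for a longer-lived compound and lower numbers for a shorter-lived compound), compound 2 (`CN(C)c1ccc2cc(-c3cc(Cl)cc(Cl)c3)c(N)nc2c1`) gives 0.17 h and compound 1 (`CN(C)c1ccc2cc(-c3ccccc3Cl)c(N)nc2c1`) gives 0.13 h, so these two sit level within the scatter of repeated measurements. Compound 3 (`CN(C)c1ccc2cc(-c3nc4cc(C(C)(C)C)ccc4o3)c(N)nc2c1`) at 1.3 h stands well clear of compound 2, beyond that scatter, and so compound 2 belongs with the short-lived end of this small set.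

Compound 4 (`CNc1ccc2cc(-c3cc(Cl)cc(Cl)c3)c(N)nc2c1`) keeps everything in compound 2 except for one small edit (hydrogen in place of methyl on a nitrogen on an aromatic ring): hydrogen in place of methyl on a nitrogen on an aromatic ring, which turns dimethylamino into methylamino. All three measured compounds carry the dimethylamino group, so none of them shows directly what this swap does, and any forecast here is a cautious one. With no evidence for a large shift in either direction, the estimated step (a 1.2-fold higher number from compound 2 to compound 4 (0.07 log units; within the scatter)) is expected to stay within the scatter of this assay rather than beyond it. For compound 4 the expected half-life is 0.2 h with an estimated range from 0.08 h to 0.5 h around it.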

Compound 4, half-life: > 4 h
Compound 4: no number, only a limit; the forecaster's own chance of this, stated with the estimate: 3%; middle value at least 20-fold (1.30 log units) from the limit.
By their numbers in this assay, from the lowest: compounds 1 and 2 (each within the scatter of the next); then compound 3. At a limit, above all of these: compound 4.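

In this assay compound 4 gives > 4 h, which is a limit of the assay and not a number. Trading dimethylamino for methylamino gives an at least 23-fold higher number from compound 2 to compound 4 (1.37 log units; beyond the scatter), so a change of one methyl on this nitrogen on an aromatic ring can carry a compound far beyond the scatter, something the earlier compounds, which all hold dimethylamino, could not show. That step gives only a floor for the size of the change, not its exact size: the limit of > 4 h in this assay, at which 1 of the 4 values shown sits.

From the compounds shown here alone, it remains open how the half-life would respond to a plain amino group on this nitrogen, with no methyl left, or to a longer chain such as ethyl. Going by these compounds, it is also open whether the same swap would do as much in compound 1 or compound 3, which carry other groups on the shared core.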